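The compounds below may be only part of what the source reports. "The series", "measured", "known", "first", "only" and "open" are said of these compounds alone.

Two compounds share the same core and differ only in the group on a saturated ring carbon. Compound 1 `c1ccc(CNC2CCN(CCCc3c[nH]c4ccc(-n5cnnc5)cc34)CC2)cc1` carries benzylamino there, and in an assay on CHO cells for displacement of a labelled ligand from 5-hydroxytryptamine receptor 1D (Homo sapiens) (a higher number here means a weaker inhibitor, a lower number a stronger inhibitor), compound 1 gives 4.6 nM. Compound 2 `CN(Cc1ccccc1)CC1CCN(CCCc2c[nH]c3ccc(-n4cnnc4)cc23)CC1` carries (benzyl(methyl)amino)methyl instead, and in this assay compound 2 gives 0.9 nM. Among the compounds with values here, that single change produced a 5.1-fold lower number from compound 1 to compound 2 (0.71 log units; beyond the scatter), so compound 2 stands with the lower of the two numbers, and its only neighbour, compound 1, sits higher by that same step.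

Compound 3 `c1cncc(CNC2CCN(CCCc3c[nH]c4ccc(-n5cnnc5)cc34)CC2)c1` is the next step. Compared with compound 2, the change is ((pyridin-3-yl)methyl)amino in place of (benzyl(methyl)amino)methyl on a saturated ring carbon. This largely undoes the earlier change: the amino group again sits directly on the ring carbon and again bears a hydrogen, while the carbon ring becomes a pyridin-3-yl ring. Within the data shown here, the only step that bears on it is the one from compound 1 to compound 2, which was modest; walked backwards it points to a higher number for compound 3. Among the measured compounds shown here, the ring swap has no measured precedent here. Compound 3 is therefore expected to move by a 5.6-fold higher number from compound 2 to compound 3 (0.74 log units; beyond the scatter), giving an estimate of 5 nM, within 1.5 nM to 15 nM.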

Compound 3, half-maximal inhibitory concentration: 35 nM
For compound 3 the middle estimate is 7.0-fold (0.85 log units) below the measured one; measured number above the stated range.
By their numbers in this assay, from the lowest: compound 2; then compound 1; then compound 3.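

In this assay, the clearest reading comes from the pair that differs only in the aromatic ring: pyridin-3-yl in place of phenyl gives a 7.6-fold higher number from compound 1 to compound 3 (0.88 log units; beyond the scatter) and shows that this ring matters to the number, which could not be seen while compound 1 and compound 2 both carried the carbon-only ring. The wider change at the saturated ring carbon gives a 39-fold higher number from compound 2 to compound 3 (1.59 log units; beyond the scatter), a large step in which the ring swap and the return to an amino group bearing a hydrogen run the same way, so the ring swap adds to the rise rather than offsetting it. No measured evidence here accounts for either step.

The compounds shown leave open whether pyridin-3-yl would cost as much when carried on the (benzyl(methyl)amino)methyl group of compound 2, since the one pyridine example sits on the shorter amino group. They also leave open how a pyridin-4-yl or pyridin-2-yl ring would compare, and how much of the gain in compound 2 comes from the methyl on the amine nitrogen rather than from the added carbon between that nitrogen and the saturated ring.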